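Working notes on chain lengthening in a growth-inhibition series

This account rests on a few compounds, and the source may have more. Where it says the series, first, only, none or still open, it means among the compounds named here.

Measured so far:
compound 1 `CCCCCCc1cc2c(=O)n(CCSc3nc(-c4cc(OC)c(OC)c(OC)c4)c(C#N)c(=O)[nH]3)cnc2s1`: 96.8 ug/mL
compound 2 `CCCc1cc2c(=O)n(CCCSc3nc(-c4cc(OC)c(OC)c(OC)c4)c(C#N)c(=O)[nH]3)cnc2s1`: > 100 ug/mL

Of the compounds shown here, two have been read in an ADME assay on A549 cells (Homo sapiens) for inhibition, read by MTT assay; a higher number here means a weaker inhibitor of growth, a lower number a stronger inhibitor of growth. Compound 1 sits just under the top of the measured range. Compound 2 reaches only the limit of > 100 ug/mL in this assay, so no number is known for it and it stands at the limit of > 100 ug/mL in this assay, at which 1 of the 2 values shown sits. Going by the values given here, no step between compound 1 and compound 2 can be drawn; their values show one reading just under the limit and one at it.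

Compound 3 `CCCCCCCc1cc2c(=O)n(CCCSc3nc(-c4cc(OC)c(OC)c(OC)c4)c(C#N)c(=O)[nH]3)cnc2s1` is not yet measured. It differs from compound 2 by butyl in place of hydrogen on a saturated chain carbon, three bonds along the chain from an aromatic carbon. Among the compounds with values here, no measured step bears on this change. Compound 1, with a reading of 96.8 ug/mL, gives no hint of any large move within the series, so no step beyond the usual scatter is expected in this assay. The step from compound 2 to compound 3 is expected to be about a number no higher from compound 2 to compound 3 (the limit leaves the size open). Compound 3 is therefore estimated at 100 ug/mL, within 50 ug/mL to 200 ug/mL, with a high chance that only a limit is reported.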

Compound 3, concentration for 50% growth inhibition: 90.5 ug/mL
Compound 3: middle estimate off by 1.1-fold (0.04 log units), on the high side; measured number inside the range.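

In this assay, butyl in place of hydrogen on a saturated chain carbon, three bonds along the chain from an aromatic carbon, gives an at least 1.1-fold lower number from compound 2 to compound 3 (0.04 log units; that floor lies within the scatter). This position therefore accepts heptyl in place of propyl with a measured number returned, yet no change beyond the scatter is established. The reading for compound 2 is a limit and not a number, so the true size of the step stays open: the limit of > 100 ug/mL in this assay, at which 1 of the 3 values shown sits.

The compounds shown leave open whether an amine or a carboxylic acid at this position, or a chain longer than heptyl, would move the reading in this assay. Going by these compounds alone, compound 1 differs from compound 3 in more than one place, so it gives no step that bears on this change.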